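This account rests on a few compounds, and the source may have more. Where it says the series, first, only, none or still open, it means among the compounds named here.

Compound 1 `Cc1ccc(NC(=O)C2CCN(C/C=C/c3ccccc3)CC2)cc1` and compound 2 `CCCCc1ccc(NC(=O)C2CCN(C/C=C/c3ccccc3)CC2)cc1` share one core and have both been tested in a functional assay on MCF7 cells (Homo sapiens) for inhibition, read by MTT assay, with a stated time of 72 h; on this read-out lower numbers stand for stronger inhibition and higher numbers for weaker inhibition. In this assay compound 1 gives 30000 nM, the highest of the two numbers measured, while compound 2 gives 5870 nM. Among the measured compounds shown here, the only measured step, a 5.1-fold lower number from compound 1 to compound 2 (0.71 log units; beyond the scatter), points toward stronger inhibition and lies beyond the scatter. Compound 3 `CCCCCc1ccc(NC(=O)C2CCN(C/C=C/c3ccccc3)CC2)cc1` has not yet been measured. It differs from compound 1 by butyl in place of hydrogen on a saturated chain carbon bound to an aromatic carbon; the change sits at the same place where compound 2 carries a propyl, so the measured step is the closest guide available, and nothing else bears on it. A step of roughly the same size is therefore expected in this assay, again in the favourable direction, possibly a little larger, though the evidence rests on a single pair and the effect of going one carbon further is not established. Compound 3 is expected to give 3500 nM, with a plausible range from 1200 nM to 10000 nM. This estimate corresponds to an expected step of an 8.6-fold lower number from compound 1 to compound 3 (0.93 log units; beyond the scatter).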

Compound 3, half-maximal inhibitory concentration: 3740 nM
Compound 3: middle estimate off by 1.1-fold (0.03 log units), on the low side, and the stated range covers the measured number.
By their numbers in this assay, from the lowest: compounds 3 and 2 (each within the scatter of the next); then compound 1.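

With compound 3, butyl in place of hydrogen on a saturated chain carbon bound to an aromatic carbon gives, in this assay, an 8.0-fold lower number from compound 1 to compound 3 (0.90 log units; beyond the scatter), so a second, longer chain at this place also stands clearly apart from the methyl of compound 1. The newer information lies further out: methyl in place of hydrogen on a saturated chain carbon, four bonds along the chain from an aromatic carbon, gives a 1.6-fold lower number from compound 2 to compound 3 (0.20 log units; within the scatter), which is within the scatter, so compounds 2 and 3 cannot be told apart and this last extension brings no readable change. Nothing available here explains why the chain affects the read-out in this way.

From the compounds shown here alone, whether a longer chain such as hexyl would keep the number level, lower it or raise it remains open, and so does the effect of a branched chain such as tert-butyl at this place. Equally open, going by these compounds, is what a chain ending in an amine or a carboxylic acid would do, since all three compounds carry plain carbon chains.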